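Swapping fluoro for cyano on compound 1

The compounds below may be only part of what the source reports. "The series", "measured", "known", "first", "only" and "open" are said of these compounds alone.

Measured so far in a physicochemical assay for lipophilicity, at pH 7.4; on this read-out higher numbers stand for higher lipophilicity and lower numbers for lower lipophilicity:
- Compound 1 (`O=C(Nc1ccc2[nH]ncc2n1)[C@H]1CCCN1C(=O)C1(c2ccc(F)cc2)CCC1`): 4.1
- Compound 2 (`CNC(=O)c1ccc(NC(=O)[C@H]2CCCN2C(=O)C2(c3cccc(Cl)c3)CCCC2)cc1`): 5.3

Compound 1 has the lower of the two numbers at 4.1 and compound 2 at 5.3 lies higher by more than the usual scatter of such measurements. These two compounds differ in several places, so their gap gives no guide to any single change.

The next compound to be measured is compound 3 (`N#Cc1ccc(C2(C(=O)N3CCC[C@@H]3C(=O)Nc3ccc4[nH]ncc4n3)CCC2)cc1`). It keeps the core of compound 1 and has cyano in place of fluoro on an aromatic carbon so that 4-fluorophenyl becomes 4-cyanophenyl.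

Among the measured compounds shown here, no measured pair shows this swap on its own, so the expectation rests on the structural change alone. A modest fall in this assay seems most likely, although a result within the scatter of compound 1 would be no surprise. The estimated step of a number 0.40 log units lower from compound 1 to compound 3 (beyond the scatter) is expected to be small and downward. For compound 3 the estimated value is 3.7 with an expected range from 3.2 to 4.2 on this reasoning.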

Compound 3, distribution coefficient: 3.4
Estimate against measurement, compound 3: 0.30 log units above; low and high end bracket the measured number.
By their numbers in this assay, from the lowest: compound 3; then compound 1; then compound 2.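

Among the compounds shown here, this is the first change that can be read on its own: with the core of compound 1 held constant, replacing fluoro with cyano on an aromatic carbon, para to a large group, gives in this assay a number 0.70 log units lower from compound 1 to compound 3 (beyond the scatter). The number at this position therefore responds to the group placed there, since a swap confined to one substituent, turning 4-fluorophenyl into 4-cyanophenyl, moves it by more than repeated measurements would usually scatter. No measurement shown accounts for the size of this step, so it stands as an observation about this one pair.

For the compounds shown here, with a single pair, it remains open whether the same swap would give a step of similar size on a different core, such as the one carried by compound 2, or at another place on the same aromatic ring. Also open, on these data alone, is how other groups on this same carbon, such as an amine, a carboxylic acid or a methoxy group, would compare with fluoro and cyano in this assay.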